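A few compounds are considered here, and "the series" means these few. Any claim that something is new, unique, unknown or untested is made for them only; others in the source may bear on it.

Measured so far:

Compound 1, `COc1ccccc1C(=O)Nc1cccc(-c2oc3cc(-c4ccc(F)cc4)ccc3c(=O)c2O)c1`: 11700 nM
Compound 2, `O=C(Nc1cccc(-c2oc3cc(-c4ccc(F)cc4)ccc3c(=O)c2O)c1)c1ccc(C(F)(F)F)cc1`: 19400 nM
Compound 3, `O=C(Nc1cccc(-c2oc3cc(-c4ccc(F)cc4)ccc3c(=O)c2O)c1)c1cccc(F)c1`: 15400 nM

All three compounds share one core and differ only in the aromatic ring attached to the carbonyl of the amide. In a functional assay on A549 cells (Homo sapiens) for antiproliferative activity, read by CCK-8 assay, with a stated time of 72 h (a lower number here means a stronger inhibitor, a higher number a weaker inhibitor), compound 3 gives the second highest of the three numbers; its nearest neighbour is compound 2 and its furthest is compound 1, and both gaps lie within the scatter of repeated measurements.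

The measured steps tell the same story. Swapping 2-methoxyphenyl for 4-(trifluoromethyl)phenyl gave a 1.7-fold higher number from compound 1 to compound 2 (0.22 log units; within the scatter), swapping it for 3-fluorophenyl gave a 1.3-fold higher number from compound 1 to compound 3 (0.12 log units; within the scatter), and going from the trifluoromethyl ring to the fluoro ring gave a 1.3-fold lower number from compound 2 to compound 3 (0.10 log units; within the scatter). None of these moves the number beyond the scatter.

Compound 4, `CCc1ccc(C(=O)Nc2cccc(-c3oc4cc(-c5ccc(F)cc5)ccc4c(=O)c3O)c2)cc1`, continues this series with another ring on the carbonyl carbon: 4-ethylphenyl in place of 3-fluorophenyl on a carbonyl carbon. Within the data shown here, since every change at this position so far has stayed within the scatter, the expected step of a 1.0-fold lower number from compound 3 to compound 4 (0.01 log units; within the scatter) in this assay is likewise expected to be no larger than the scatter, with no clear direction. Compound 4 is therefore estimated at 15000 nM, with a range from 6000 nM to 38000 nM.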

Compound 4, half-maximal inhibitory concentration: 18500 nM
For compound 4 the middle estimate is 1.2-fold (0.09 log units) below the measured one; low and high end bracket the measured number.
By their numbers in this assay, from the lowest: compounds 1, 3, 4 and 2 (each within the scatter of the next).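

In this assay, the 4-ethylphenyl ring brings a plain carbon chain to the carbonyl carbon, where the earlier rings carried methoxy, trifluoromethyl or fluoro groups, yet the result stays within the scatter of all three neighbours (a 1.2-fold higher number from compound 3 to compound 4 (0.08 log units; within the scatter); a 1.6-fold higher number from compound 1 to compound 4 (0.20 log units; within the scatter); a 1.0-fold lower number from compound 2 to compound 4 (0.02 log units; within the scatter)). The step from compound 2 is the most direct of these, since it is only ethyl in place of trifluoromethyl on an aromatic carbon, and a group with no fluorine still leaves the number within the scatter of the one with three fluorines. Four different rings at this place now give numbers within the scatter of one another, and nothing measured here accounts for that sameness.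

Still open, as far as these compounds go, is whether a ring is needed at this place at all, and whether a ring bearing an amine or a carboxylic acid, or a longer chain in place of ethyl, would move the number beyond the scatter. The shared core stays the same throughout, which leaves open whether this sameness would hold on a different core.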